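The source may hold more compounds than are shown below. What is called first, only, known or untested is meant among the compounds shown, and "the series" means these compounds.

In an ADME assay on Raji cells (Homo sapiens) for cytotoxicity, with a stated time of 72 h (a lower number here means that less compound is needed, a higher number that more compound is needed for the effect), compound 2 (`O=C(Nc1nc2ccc(Cl)cc2s1)c1cc([N+](=O)[O-])ccc1Cl`) gives > 27000 nM, which is a limit and not a number. Compound 1 (`O=C(O)COc1cc(Cl)c(C(=O)Nc2cccc(-c3nc4ccccc4s3)c2)cc1[N+](=O)[O-]`) gives > 25000 nM, also a limit. Compound 3 (`O=C(Nc1cccc(-c2nc3ccccc3s2)c1)c1cc([N+](=O)[O-])c(O)cc1Cl`) gives > 25000 nM, again a limit. Compound 4 (`O=C(Nc1nc2ccc(F)cc2s1)c1cc([N+](=O)[O-])ccc1Cl`) departs from compound 2 at one place, with fluoro in place of chloro on an aromatic carbon. Among the compounds with values here, the only measured step is a step that the two limits leave unreadable from compound 1 to compound 3. It concerns a different change on a different pair, so it offers no size to carry over to this exchange. Starting from compound 2 and its limit of > 27000 nM, no step beyond the scatter is expected in this assay, and the measurement may well return a limit again. The expected change is a step that the limit leaves unreadable from compound 2 to compound 4. For compound 4, the estimated value is 30000 nM, with an expected range from 15000 nM to 60000 nM.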

Compound 4, half-maximal effective concentration in the Raji assay: > 27000 nM
Compound 4: a limit, no number (the forecaster's own chance of this, stated with the estimate: 85%); the middle value does not contradict the limit.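

In the Raji assay compound 2 gives > 27000 nM, which is a limit and not a number. In the Raji assay compound 4 gives > 27000 nM, also a limit. No step can be read for fluoro in place of chloro on an aromatic carbon. The compounds shown leave open at what concentration any of them reaches the half-maximal effect in the Raji assay. In a physicochemical assay for solubility, read by spectrophotometry, in phosphate buffer, measured as kinetic solubility, with a stated time of 18 h, at pH 7.4 (on this read-out higher numbers stand for higher solubility and lower numbers for lower solubility), compound 2 gives 1200 nM and compound 4 gives 570 nM. In the physicochemical assay the same exchange gives a 2.1-fold lower number from compound 2 to compound 4 (0.32 log units; beyond the scatter).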